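A few compounds are considered here, and "the series" means these few. Any claim that something is new, unique, unknown or untested is made for them only; others in the source may bear on it.

Measured in a functional assay on NCI-H322 cells (Homo sapiens) for antiproliferative activity; a lower number here means a stronger inhibitor of growth, a higher number a weaker inhibitor of growth:
- compound 1 `COCCCCCCCCCCCCCCC/C=C1\CC(CO)(COC(=O)C(C)(C)C)OC1=O`: > 10 ug/mL (a limit)
- compound 2 `COCCCCCCCCCCC/C=C1\CC(CO)(COC(=O)C(C)(C)C)OC1=O`: > 10 ug/mL (a limit)
- compound 3 `CC(C)(C)C(=O)OCC1(CO)C/C(=C\CCCCCCCCCCCO)C(=O)O1`: > 10 ug/mL (a limit)

Compound 3 gives no number, only the limit > 10 ug/mL. Among the compounds with values here, it shares this position with the other two compounds, as the series so far offers only (the limit of > 10 ug/mL in this assay, at which 3 of the 3 values shown sit).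

The next compound is compound 4 `CC(C)(C)C(=O)OCC1(CO)C/C(=C\CCCCCCCCCCCCCCC=O)C(=O)O1`. The change is 3-formylpropyl in place of hydroxy on a saturated chain carbon, ten or more bonds along the chain from a double-bonded chain carbon.

Within the data shown here, the steps that bear on it all alter the same chain end: a step that the two limits leave unreadable from compound 1 to compound 3, a step that the two limits leave unreadable from compound 2 to compound 3 and a step that the two limits leave unreadable from compound 1 to compound 2. None of them has a readable size, so none sets a direction. All three chain ends tried so far stay at the limit, and no step beyond the scatter is expected in this assay. The expected change is a step that the limit leaves unreadable from compound 3 to compound 4, and a report as a limit alone is the likeliest outcome. For compound 4 the estimate is 14 ug/mL, with an expected range of 6 ug/mL to 40 ug/mL.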

Compound 4, concentration for 50% growth inhibition: > 10 ug/mL
Compound 4: only a limit was reported (the forecaster's own chance of this, stated with the estimate: 75%); the middle value lies beyond the limit too.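

Compound 4 gives only a limit in this assay, > 10 ug/mL, so its steps from compound 1, compound 2 and compound 3 cannot be read. The compounds shown leave open whether these chain ends differ at all in this assay, as all four values share one limit: the limit of > 10 ug/mL in this assay, at which 4 of the 4 values shown sit.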